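The compounds below may be only part of what the source reports. "The series", "measured", "known", "first", "only" and "open" are said of these compounds alone.

Three compounds have been examined in a functional assay on MCF7 cells (Homo sapiens) for cytotoxicity, read by MTT assay, with a stated time of 72 h, tested at 100 uM; on this read-out lower numbers stand for less inhibition of growth and higher numbers for more inhibition of growth at the one concentration tested. Compound 1 `N/C(=N\NC(=S)N1CCN(c2ccccn2)CC1)c1ccc(F)cn1` stands highest of the three on the numbers shown: in this assay compound 1 gives 74.3%. Its nearest neighbour is compound 2 `Cc1cccc(/C(N)=N/NC(=S)N2CCCC2)n1`, which in this assay gives 61.8%, a number that lies below compound 1 by more than the scatter. Furthest away is compound 3 `Cc1ccnc(/C(N)=N/NC(=S)N2CCOCC2)c1`, which in this assay gives 12.8%, far below compound 1. No two of these compounds differ in a single place, so what separates them can be read only from their values and not traced to one change.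

Compound 4 `Cc1cccc(/C(N)=N/NC(=S)N2CCN(c3ccccn3)CC2)n1` has not yet been measured. It differs from compound 1 in one place: 6-methylpyridin-2-yl in place of 5-fluoropyridin-2-yl on a carbon with a double bond to nitrogen. The rest of compound 1 is kept unchanged.

Compound 2 carries the same 6-methylpyridin-2-yl group on the carbon with a double bond to nitrogen and gives 61.8%, a value that is high though short of compound 1. The step from compound 1 to compound 4 is therefore expected to be small and downward, perhaps no larger than the scatter: a number 9.3 percentage points lower from compound 1 to compound 4 (within the scatter). Compound 4 is estimated to give 65% in this assay, within a range from 40% to 85%.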

Compound 4, percent growth inhibition at one concentration: 49.8%
Compound 4: the middle estimate sits 15.2 percentage points above what was measured; measured number inside the range.
By their numbers in this assay, from the lowest: compound 3; then compound 4; then compound 2; then compound 1.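

In this assay, putting 6-methylpyridin-2-yl in place of 5-fluoropyridin-2-yl on a carbon with a double bond to nitrogen gives a number 24.5 percentage points lower from compound 1 to compound 4 (beyond the scatter), the first difference in this set that can be traced to one change. It shows that the read-out responds to this place in the structure even though the piperazine-free description of the change is slight: the two groups match in heavy-atom count, in their single six-membered aromatic ring with one hetero atom, in hydrogen-bond donors and acceptors, and in net charge, so none of these counts accounts for the step. Nothing available bears on why the exchange lowers the number.

This single step changes both the substituent and its place on the pyridine ring, so the contributions of the two cannot be separated. Pyridin-2-yl with no substituent, 5-methylpyridin-2-yl and 6-fluoropyridin-2-yl at the same carbon would be needed to tell them apart, and whether the step holds with the pyrrolidine or morpholine of the other compounds also remains open.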